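Acetyl in Place of Ethoxycarbonyl on the Second Core

The compounds below may be only part of what the source reports. "The series", "measured", "known", "first", "only" and "open" are said of these compounds alone.

Compound 1 `C=C(C)[C@@H]1CC=C(Cn2cc(COc3ccc(C4NC(=O)NC(C)=C4C(=O)OCC)cc3)nn2)CC1`: 92200 nM
Compound 2 `C=C(C)[C@@H]1CC=C(Cn2cc(COc3cccc(C4NC(=O)NC(C)=C4C(=O)OCC)c3)nn2)CC1`: > 100000 nM, a limit of the assay
Compound 3 `C=C(C)[C@@H]1CC=C(Cn2cc(COc3ccc(C4NC(=O)NC(C)=C4C(C)=O)cc3)nn2)CC1`: 49300 nM

All three were tested in a functional assay on PC-3 cells (Homo sapiens) for inhibition, read by sulforhodamine B assay, with a stated time of 48 h; a lower number here means a stronger inhibitor of growth, a higher number a weaker inhibitor of growth. Compound 1 gives 92200 nM and compound 3 gives 49300 nM. For compound 2 only a limit is known, > 100000 nM, so it sits at the limit of > 100000 nM in this assay, at which 1 of the 3 values shown sits. The difference between the core of compound 1 and the core of compound 2 is not broken down here.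

Compound 3 differs from compound 1 by methyl in place of ethoxy on a carbonyl carbon, and this gave a 1.9-fold lower number from compound 1 to compound 3 (0.27 log units; within the scatter). Compound 4 `C=C(C)[C@@H]1CC=C(Cn2cc(COc3cccc(C4NC(=O)NC(C)=C4C(C)=O)c3)nn2)CC1` is not yet measured; it differs from compound 2 by methyl in place of ethoxy on a carbonyl carbon, the same change on the other core. Because the measured step of a 1.9-fold lower number from compound 1 to compound 3 (0.27 log units; within the scatter) stayed within the scatter, a step of similar small size is expected from compound 2 to compound 4, an at least 1.1-fold lower number from compound 2 to compound 4 (0.04 log units; that floor lies within the scatter), and since compound 2 shows only a limit, compound 4 is expected to give about 90000 nM, with a fair chance of another limit.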

Compound 4, concentration for total growth inhibition: 49800 nM
Beside the measured number, compound 4's estimate is 1.8-fold (0.26 log units) above it; the range from low to high includes it.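

In this assay, acetyl in place of ethoxycarbonyl on the core of compound 2 gives an at least 2.0-fold lower number from compound 2 to compound 4 (0.30 log units; that floor lies within the scatter), and the two cores can be set side by side: the same change on two cores in this assay, a 1.9-fold lower number (0.27 log units; within the scatter) from compound 1 to compound 3 and an at least 2.0-fold lower number (0.30 log units; that floor lies within the scatter) from compound 2 to compound 4; the limit leaves it open whether they differ

On these data alone, compound 2 reads > 100000 nM, which is a limit of the assay and not a number, so the true size of the step on this core remains unknown. The result fits the change carrying over from the core of compound 1 to the core of compound 2, but it does not show that the step has the same size on both, nor that the change gives a real gain on either core, since the step on the core of compound 1 and the floor of the step on the core of compound 2 both lie within the scatter.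

The compounds shown leave open what other groups on this carbonyl carbon, such as a carboxylic acid, a primary amide or a longer ester chain, would do on either core. They also leave open whether any such group would move the growth-inhibition reading beyond the scatter.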